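Shortening the Chain on the Shared Core

A few compounds are considered here, and "the series" means these few. Any claim that something is new, unique, unknown or untested is made for them only; others in the source may bear on it.

Measured compounds:
compound 1 `CCCCc1ccc(C#Cc2cn(C/C=C\CN3C(=O)c4ccccc4C3=O)c(=O)[nH]c2=O)cc1` — 23000 nM
compound 2 `CCCCCc1ccc(C#Cc2cn(C/C=C/CN3C(=O)c4ccccc4C3=O)c(=O)[nH]c2=O)cc1` — 23000 nM

Both were tested in a functional assay on CCRF-CEM cells (Homo sapiens) for antiproliferative activity, read by MTT assay, with a stated time of 3 days; a higher number here means a weaker inhibitor, a lower number a stronger inhibitor. Compound 2 gives 23000 nM, level at the digits shown with compound 1, which gives 23000 nM; the two values lie within the scatter of each other. Compound 3 `CCCCc1ccc(C#Cc2cn(C/C=C/CN3C(=O)c4ccccc4C3=O)c(=O)[nH]c2=O)cc1` differs from compound 2 by hydrogen in place of methyl on a saturated chain carbon, four bonds along the chain from an aromatic carbon. Among the measured compounds shown here, no step between measured compounds isolates this change, and the two measured values show no difference beyond the scatter. The step from compound 2 to compound 3 in this assay is expected to be no change at the digits printed from compound 2 to compound 3 (within the scatter), none beyond the scatter. Compound 3 is therefore estimated at 23000 nM, in the range 10000 nM to 50000 nM.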

Compound 3, half-maximal inhibitory concentration: 31000 nM
For compound 3 the middle estimate is 1.3-fold (0.13 log units) below the measured one, within the range that was stated.
By their numbers in this assay, from the lowest: compounds 1, 2 and 3 (each within the scatter of the next).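

In this assay, hydrogen in place of methyl on a saturated chain carbon, four bonds along the chain from an aromatic carbon, gives a 1.3-fold higher number from compound 2 to compound 3 (0.13 log units; within the scatter), so this change now has a step of its own and it does not register beyond the scatter. Compound 3 also supplies a 1.3-fold higher number from compound 1 to compound 3 (0.13 log units; within the scatter), which reads the double bond drawn Z against E directly, with nothing else altered: the fact that compounds 1 and 3 differ only in the configuration as drawn. From the compounds shown here alone, what an amine, a carboxylic acid or a longer chain would do in place of this chain remains open, as does whether double-bond configuration would count alongside such a group.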